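Replacing Benzyl with Phenylcarbamoyl: Expected Cytotoxicity Shift

This account rests on a few compounds, and the source may have more. Where it says the series, first, only, none or still open, it means among the compounds named here.

Of the compounds shown here, three sharing one core have been measured in an ADME assay on MT4 cells (Homo sapiens) for cytotoxicity, read by MTT assay, with a stated time of 4 days; on this read-out lower numbers stand for higher toxicity in this test and higher numbers for lower toxicity in this test. Compound 1 `CC(=O)Nc1c(C)c(C(OC(C)(C)C)C(=O)O)c(-c2ccc(C)c(C)c2)c(C)c1-c1ccc(C)c(C)c1` gives 19000 nM, and compound 2 `CCC(=O)Nc1c(C)c(C(OC(C)(C)C)C(=O)O)c(-c2ccc(C)c(C)c2)c(C)c1-c1ccc(C)c(C)c1` gives 15000 nM; the step of a 1.3-fold lower number from compound 1 to compound 2 (0.10 log units; within the scatter) is small. Compound 3 `Cc1ccc(-c2c(C)c(-c3ccc(C)c(C)c3)c(C(OC(C)(C)C)C(=O)O)c(C)c2NCc2ccccc2)cc1C` gives 4000 nM, the lowest number of the three and therefore the most toxic in this assay, with the benzyl group on the ring nitrogen where compounds 1 and 2 carry acetyl and propanoyl.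

Compound 4 `Cc1ccc(-c2c(C)c(-c3ccc(C)c(C)c3)c(C(OC(C)(C)C)C(=O)O)c(C)c2NC(=O)Nc2ccccc2)cc1C` is not yet measured. It differs from compound 3 by phenylcarbamoyl in place of benzyl on a nitrogen on an aromatic ring, so a carbonyl and an amide-type hydrogen return to the nitrogen, as in compounds 1 and 2. For the measured compounds named here, the steps that bear on this are a 4.8-fold lower number from compound 1 to compound 3 (0.68 log units; beyond the scatter) and a 3.8-fold lower number from compound 2 to compound 3 (0.57 log units; beyond the scatter), both going toward more toxicity when an acyl group is exchanged for benzyl. Reversing that kind of exchange suggests the number should rise again, though the phenylcarbamoyl group is larger than either acyl group, so the size is uncertain. For compound 4 the estimated step is a 2.5-fold higher number from compound 3 to compound 4 (0.40 log units; beyond the scatter), giving an expected value of 10000 nM within a range from 4000 nM to 30000 nM.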

Compound 4, half-maximal cytotoxic concentration: 8000 nM
For compound 4 the middle estimate is 1.3-fold (0.10 log units) above the measured one, and the stated range covers the measured number.
By their numbers in this assay, from the lowest: compounds 3, 4, 2 and 1 (each within the scatter of the next, the first and the last beyond it).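

In this assay, phenylcarbamoyl in place of benzyl on this nitrogen stays within the scatter (a 2.0-fold higher number from compound 3 to compound 4 (0.30 log units; within the scatter)), so bringing back a carbonyl and an amide-type hydrogen in this form gives no clear change. Anilino in place of ethyl on the carbonyl carbon also stays within the scatter (a 1.9-fold lower number from compound 2 to compound 4 (0.27 log units; within the scatter)), while anilino in place of methyl reads modestly beyond it (a 2.4-fold lower number from compound 1 to compound 4 (0.38 log units; beyond the scatter)), which places this larger group among the others without a clean separation. Nothing available here explains these numbers. Still open, going by these compounds, is whether the phenyl ring of phenylcarbamoyl matters, as a cyclohexyl ring in its place would test. Also open, on these data alone, is how a free amine or a methanesulfonyl group on this nitrogen would read.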